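The source may hold more compounds than are shown below. What is called first, only, known or untested is meant among the compounds shown, and "the series" means these compounds.

Measured compounds and their numbers in an assay on tissue (HeLa cells) for inhibition of Indoleamine 2,3-dioxygenase 1 (Homo sapiens), with stated times of 2 h and 18 h; a lower number here means a stronger inhibitor, a higher number a weaker inhibitor:

Compound 1, `C[C@@H](NCc1ccc(Cl)cc1)[C@H]1CC[C@@H](c2ccnc3ccc(F)cc32)CC1`: in this assay compound 1 gives 745 nM.
Compound 2, `C[C@@H](NS(=O)(=O)c1ccc(Cl)cc1)[C@H]1CC[C@@H](c2ccnc3ccc(F)cc32)CC1`: in this assay compound 2 gives > 1000 nM, a limit of the assay rather than a number.
Compound 3, `C[C@@H](NC(=O)Nc1ccc(Cl)cc1)[C@H]1CC[C@@H](c2ccnc3ccc(F)cc32)CC1`: in this assay compound 3 gives 20 nM.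

Compound 3 has the lowest of the two numbers given here; its nearest neighbour is compound 1, with a 37-fold lower number from compound 1 to compound 3 (1.57 log units; beyond the scatter), while an at least 50-fold lower number from compound 2 to compound 3 (1.69 log units; beyond the scatter) rests on a limit, as the limit of > 1000 nM in this assay, at which 1 of the 3 values shown sits, shows. The step from compound 1 to compound 2 is small, an at least 1.3-fold higher number from compound 1 to compound 2 (0.12 log units; that floor lies within the scatter).

Compound 4, `C[C@@H](NC(=O)c1cccc(Cl)c1)[C@H]1CC[C@@H](c2ccnc3ccc(F)cc32)CC1`, is to be measured in this assay. It differs from compound 3 in one place: 3-chlorophenyl in place of (4-chlorophenyl)amino on a carbonyl carbon. For the measured compounds named here, no measured pair changes this part of the structure; the two large steps measured, from compound 1 and from compound 2 to compound 3, show that what is attached to the amine nitrogen sets the number strongly, and that the (4-chlorophenyl)carbamoyl group stands out from the alternatives tried. Compound 4 keeps the carbonyl on that nitrogen but removes the (4-chlorophenyl)amino part, so a step back upward is expected, though smaller than those two steps. Compound 4 is estimated at 120 nM, between 30 nM and 500 nM, an expected step of a 6.0-fold higher number from compound 3 to compound 4 (0.78 log units; beyond the scatter).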

Compound 4, half-maximal inhibitory concentration: 7 nM
Beside the measured number, compound 4's estimate is 17-fold (1.23 log units) above it; the measured number lies below the stated range.
By their numbers in this assay, from the lowest: compound 4; then compound 3; then compound 1. At a limit, above all of these: compound 2.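

For the compounds shown here, the carbonyl carbon tolerates the loss of (4-chlorophenyl)amino, and with it a hydrogen-bond donor: in this assay, replacing that group with 3-chlorophenyl gives a 2.9-fold lower number from compound 3 to compound 4 (0.46 log units; beyond the scatter), so the (4-chlorophenyl)carbamoyl group is not the only group on the amine nitrogen that gives a low number. Going by these compounds alone, the distance from the benzyl-bearing amine is also wider than the earlier compounds showed, with (3-chlorophenyl)carbonyl on that nitrogen giving a 110-fold lower number from compound 1 to compound 4 (2.03 log units; beyond the scatter). The contrast with the sulfonyl compound is likewise large, an at least 140-fold lower number from compound 2 to compound 4 (2.15 log units; beyond the scatter), but this step rests on compound 2, whose value is a limit and not a number: the limit of > 1000 nM in this assay, at which 1 of the 4 values shown sits.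

The step to compound 4 changes both the group on the carbonyl carbon and the ring's chlorine placement, so the compounds shown leave open how much of the gain belongs to the loss of the amino nitrogen and how much to 3-chlorophenyl as against 4-chlorophenyl. They also leave open whether a nitrile or a methoxy group could stand in for the chlorine, and whether a longer chain on the carbonyl carbon would keep the number this low.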